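Hydroxy in Place of Methyl: Expected Cytotoxicity of Compound 4

The source may hold more compounds than are shown below. What is called first, only, known or untested is meant among the compounds shown, and "the series" means these compounds.

compound 1 `Cc1ccc(S(=O)(=O)Nc2ccc(-c3nc4ccccc4o3)cc2)cc1` 88000 nM
compound 2 `O=S(=O)(Nc1ccc2oc(-c3ccccc3)nc2c1)c1cccc(F)c1` 68000 nM
compound 3 `O=S(=O)(Nc1ccc2oc(-c3ccccc3)nc2c1)c1ccccc1F` 72000 nM

In an ADME assay on HEK293 cells (Homo sapiens) for cytotoxicity, read by resazurin assay, with a stated time of 48 h (on this read-out higher numbers stand for lower toxicity in this test and lower numbers for higher toxicity in this test), compound 1 gives 88000 nM, the highest of the three numbers, although compound 3 with 72000 nM and compound 2 with 68000 nM both lie within the scatter of it. Compound 4 `O=S(=O)(Nc1ccc(-c2nc3ccccc3o2)cc1)c1ccc(O)cc1` differs from compound 1 by hydroxy in place of methyl on an aromatic carbon. Within the data shown here, the only measured step, a 1.1-fold higher number from compound 2 to compound 3 (0.02 log units; within the scatter), concerns the ring on the sulfonyl sulfur as well, but it moves a fluorine rather than exchanging methyl for hydroxy, so it bears only loosely on this change. With so little to go on, no step beyond the scatter is expected, and compound 4 is estimated at 80000 nM, between 40000 nM and 160000 nM, a step of a 1.1-fold lower number from compound 1 to compound 4 (0.04 log units; within the scatter).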

Compound 4, half-maximal cytotoxic concentration: > 100000 nM
Compound 4 gave a limit, no number (the forecaster's own chance of this, stated with the estimate: 10%); middle value at least 1.2-fold (0.09 log units) from the limit.
By their numbers in this assay, from the lowest: compounds 2, 3 and 1 (each within the scatter of the next). At a limit, above all of these: compound 4.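

Compound 4 stands at a limit and not at a number: the limit of > 100000 nM in this assay, at which 1 of the 4 values shown sits.

Hydroxy in place of methyl on an aromatic carbon, para to a large group, gives an at least 1.1-fold higher number from compound 1 to compound 4 (0.05 log units; that floor lies within the scatter), so the floor of this step does not separate the two compounds. Even so, the hydrogen-bond donor and acceptor that enter with hydroxy bring no sign of higher toxicity in this assay, which the fluorine compounds could not show.

As far as these compounds go, the actual value of compound 4 stays open. So does whether an amine or a methoxy group on the same carbon would read alike.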